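A few compounds are considered here, and "the series" means these few. Any claim that something is new, unique, unknown or untested is made for them only; others in the source may bear on it.

Three amides of the shared core have numbers in a functional assay on A20 cells (Mus musculus) for inhibition, with stated times of 1 h, 16 h and 24 h; on this read-out lower numbers stand for stronger inhibition and higher numbers for weaker inhibition. Compound 1 (`N#CC1(NC(=O)[C@@H]2C[C@@H](S(=O)(=O)c3ccccc3)C[C@H]2C(=O)N2CCOCC2)CC1`), carrying morpholin-4-yl, gives 12 nM. Compound 2 (`C[C@@H]1CN(C(=O)[C@@H]2C[C@H](S(=O)(=O)c3ccccc3)C[C@H]2C(=O)NC2(C#N)CC2)C[C@H](C)O1`), carrying 2,6-dimethylmorpholin-4-yl, gives 1 nM. Compound 3 (`N#CC1(NC(=O)[C@@H]2C[C@@H](S(=O)(=O)c3ccccc3)C[C@H]2C(=O)N2CCCC2)CC1`), carrying pyrrolidin-1-yl, gives 29 nM, the highest number of the three and the weakest inhibition in this small set.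

The next compound is compound 4 (`N#CC1(NC(=O)[C@@H]2C[C@@H](S(=O)(=O)c3ccccc3)C[C@H]2C(=O)N2CCC2)CC1`), not yet measured, with azetidin-1-yl in place of pyrrolidin-1-yl on a carbonyl carbon. For the measured compounds named here, no measured step makes this exact change, so the evidence is indirect. All three measured steps sit on the same carbonyl carbon. Exchanging morpholin-4-yl for pyrrolidin-1-yl gave a 2.4-fold higher number from compound 1 to compound 3 (0.38 log units; beyond the scatter), a modest step. The two large steps, a 12-fold lower number from compound 1 to compound 2 (1.08 log units; beyond the scatter) and a 29-fold higher number from compound 2 to compound 3 (1.46 log units; beyond the scatter), both involve the 2,6-dimethylmorpholin-4-yl group of compound 2, which plays no part in the present change. The modest step is therefore the closer guide, and no step beyond the scatter is expected in this assay, with neither direction favoured. The expected step is a 1.0-fold higher number from compound 3 to compound 4 (0.01 log units; within the scatter). The estimate for compound 4 is 30 nM, with an expected range of 10 nM to 90 nM.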

Compound 4, half-maximal inhibitory concentration: 44 nM
Compound 4: the middle estimate sits 1.5-fold (0.17 log units) below what was measured; the range from low to high includes it.
By their numbers in this assay, from the lowest: compound 2; then compound 1; then compounds 3 and 4 (each within the scatter of the next).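

In this assay, the azetidin-1-yl amide and the pyrrolidin-1-yl amide cannot be told apart (a 1.5-fold higher number from compound 3 to compound 4 (0.18 log units; within the scatter)), so on this carbonyl carbon the change from a five-membered to a four-membered ring leaves the number within the scatter. The azetidin-1-yl amide keeps the distance already seen for the pyrrolidin-1-yl amide from the two morpholine amides, with a modest step from the unsubstituted one (a 3.7-fold higher number from compound 1 to compound 4 (0.56 log units; beyond the scatter)) and a large step from the dimethylated one (a 44-fold higher number from compound 2 to compound 4 (1.64 log units; beyond the scatter)), so among these four compounds the clear differences all involve a morpholine amide, and the largest involve 2,6-dimethylmorpholin-4-yl. No supporting data bear on why the two smaller rings read alike or why the morpholine amides differ from them.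

Still open, as far as these compounds go, is where piperidin-1-yl, the six-membered ring without the morpholine oxygen, would fall relative to the morpholin-4-yl and pyrrolidin-1-yl amides. Also open, from the compounds shown here alone, is whether a single methyl, as in 2-methylmorpholin-4-yl, or methyl groups on a pyrrolidin-1-yl or azetidin-1-yl ring would move the number as the two methyl groups of 2,6-dimethylmorpholin-4-yl do.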